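Imine series: shortening the alkyl group on the double-bonded nitrogen

This account rests on a few compounds, and the source may have more. Where it says the series, first, only, none or still open, it means among the compounds named here.

Measured so far:
compound 1, `CCC(CC)/N=c1\c(O)c(O)\c1=N/Cc1ccc(C#N)cc1`, 1300 nM
compound 2, `CC(C)(C)/N=c1\c(O)c(O)\c1=N/Cc1cccc(F)c1`, 2400 nM
compound 3, `CCC(C)(C)/N=c1\c(O)c(O)\c1=N/Cc1c(C)cccc1Cl`, 4400 nM

In a functional assay for inhibition, with Rattus norvegicus as the target (on this read-out higher numbers stand for weaker inhibition and lower numbers for stronger inhibition), compound 1 gives the lowest of the three numbers. The number for compound 2 sits within the scatter of it, so no order between the two can be read; the number for compound 3 lies beyond the scatter above compound 1.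

Compound 4, `C/N=c1\c(O)c(O)\c1=N/Cc1ccc(C#N)cc1`, is not yet measured. It differs from compound 1 in one place: methyl in place of pentan-3-yl on a double-bonded nitrogen. Within the data shown here, no measured pair shows this change, so its effect is untested here. The expectation is a modest move towards weaker inhibition, a 2.3-fold higher number from compound 1 to compound 4 (0.36 log units; beyond the scatter), possibly beyond the scatter. For compound 4 the estimate in this assay is 3000 nM, with a range from 900 nM to 10000 nM.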

Compound 4, half-maximal inhibitory concentration: > 30000 nM
Compound 4: only a limit was reported; the forecaster's own chance of this, stated with the estimate: 10%; middle value at least 10-fold (1.00 log units) away from the limit.
By their numbers in this assay, from the lowest: compounds 1, 2 and 3 (each within the scatter of the next, the first and the last beyond it). At a limit, above all of these: compound 4.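

In this assay, the group on the double-bonded nitrogen proves not to be interchangeable: methyl in place of pentan-3-yl gives an at least 23-fold higher number from compound 1 to compound 4 (1.36 log units; beyond the scatter), the first single-place change readable in this series. Compound 4 stands only at a limit, > 30000 nM. The printed step therefore gives only a bound on the size of the change: the limit of > 30000 nM in this assay, at which 1 of the 4 values shown sits.

An ethyl or a propyl group on this nitrogen would show whether inhibition fades stepwise or falls away at once between pentan-3-yl and methyl. Compound 2 and compound 3 differ from compound 1 in more than one place, so they do not settle this.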